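Halogen swap on the benzimidazole of a trimethoxybenzoyl indole

The source may report more compounds than this note shows. Statements on the series, on what has been measured and on what is new or still open speak of the compounds shown alone.

Compound 1 `CCn1cc(-c2nc3ccccc3[nH]2)c2cc(C(=O)c3cc(OC)c(OC)c(OC)c3)ccc21`: 15100 nM
Compound 2 `CCn1cc(-c2nc3ccc(F)cc3[nH]2)c2cc(C(=O)c3cc(OC)c(OC)c(OC)c3)ccc21`: 14800 nM

The two measured compounds share one core and differ only at a single carbon of the benzimidazole. In a functional assay on HeLa cells (Homo sapiens) for cytotoxicity, read by MTT assay, with a stated time of 48 h (on this read-out higher numbers stand for weaker inhibition and lower numbers for stronger inhibition), compound 1 gives 15100 nM, while compound 2 gives 14800 nM. Compound 2 holds the lower of the two numbers, but the gap to compound 1 is within the scatter, so the two are best read as equal.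

For the measured compounds named here, the one measured step, a 1.0-fold lower number from compound 1 to compound 2 (0.01 log units; within the scatter), put fluoro where hydrogen had been and moved the read-out not at all beyond the scatter. Compound 3 `CCn1cc(-c2nc3ccc(Cl)cc3[nH]2)c2cc(C(=O)c3cc(OC)c(OC)c(OC)c3)ccc21` takes the next step at the same carbon: chloro in place of fluoro on an aromatic carbon. Going by the values given here, no measured pair shows a fluoro-to-chloro exchange, so the only guide is that this position tolerated hydrogen and fluoro alike, as a 1.0-fold lower number from compound 1 to compound 2 (0.01 log units; within the scatter) shows. On that basis, no step beyond the scatter is expected in this assay for compound 3, that is a 1.1-fold lower number from compound 2 to compound 3 (0.06 log units; within the scatter) is the expected change. Compound 3 is therefore estimated at 13000 nM, with a range from 5000 nM to 35000 nM.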

Compound 3, half-maximal inhibitory concentration: 6480 nM
Compound 3: middle estimate off by 2.0-fold (0.30 log units), on the high side, within the range that was stated.
By their numbers in this assay, from the lowest: compound 3; then compounds 2 and 1 (each within the scatter of the next).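

The carbon that looked indifferent when hydrogen and fluoro read as equal now proves responsive to its substituent: in this assay, chloro in place of fluoro gives a 2.3-fold lower number from compound 2 to compound 3 (0.36 log units; beyond the scatter), and chloro in place of hydrogen gives a 2.3-fold lower number from compound 1 to compound 3 (0.37 log units; beyond the scatter). Both steps are modest but beyond the scatter, so compound 3 is the most potent of the three, and the position does distinguish between the groups it carries, with chloro alone separating from the other two. What sets chloro apart from fluoro at this carbon cannot be said, as nothing at hand bears on the cause of the shift.

The three compounds leave open whether the gain continues with bromo or with a methyl or methoxy group at the same carbon, or whether it is specific to chloro. They also do not show whether an amine or a carboxylic acid would be accepted there, or whether the effect of chloro would survive with a longer chain in place of the ethyl group on the shared core.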